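From Dimethoxyphenyl to 4-Bromophenyl on a Shared Core

The compounds below may be only part of what the source reports. "The series", "measured", "known", "first", "only" and "open" are said of these compounds alone.

- compound 1 `COc1ccc(/C=C/C(=O)Nc2cc3c(Nc4ccc(F)c(Cl)c4)ncnc3cc2O[C@H]2CCOC2)c(OC)c1` gives 26500 nM
- compound 2 `COc1cc(/C=C/C(=O)Nc2cc3c(Nc4ccc(F)c(Cl)c4)ncnc3cc2O[C@H]2CCOC2)cc(OC)c1` gives 34300 nM
- compound 3 `O=C(/C=C/c1ccc(Br)cc1)Nc1cc2c(Nc3ccc(F)c(Cl)c3)ncnc2cc1O[C@H]1CCOC1` has no measured value yet

In a functional assay on HeLa cells (Homo sapiens) for cytotoxicity, read by MTT assay, with a stated time of 72 h (on this read-out lower numbers stand for stronger inhibition and higher numbers for weaker inhibition), compound 2 gives 34300 nM, and compound 1 gives 26500 nM. Among the measured compounds shown here, these two numbers cannot be told apart, so compound 2 stands level with the only other measured compound.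

Compound 3 keeps the shared core and the amide chain of compound 2, but 4-bromophenyl takes the place of 3,5-dimethoxyphenyl on a double-bonded chain carbon bound to a double-bonded chain carbon: 4-bromophenyl in place of 3,5-dimethoxyphenyl on a double-bonded chain carbon bound to a double-bonded chain carbon.

For the measured compounds named here, only one measured step bears on this change: a 1.3-fold higher number from compound 1 to compound 2 (0.11 log units; within the scatter). It swapped 2,4-dimethoxyphenyl for 3,5-dimethoxyphenyl at the same place, so it is only an indirect guide. Going by the values given here, no measured compound carries 4-bromophenyl, which makes the forecast uncertain. With so little to go on, no shift beyond the scatter is expected in this assay, and the expected step is a 1.2-fold lower number from compound 2 to compound 3 (0.09 log units; within the scatter). The estimated value for compound 3 is 28000 nM, with an expected range from 12000 nM to 60000 nM.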

Compound 3, half-maximal inhibitory concentration: 27500 nM
Compound 3: middle estimate off by 1.0-fold (0.01 log units), on the high side; the range from low to high includes it.
By their numbers in this assay, from the lowest: compounds 1, 3 and 2 (each within the scatter of the next).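

In this assay, the first direct test of a group with no methoxy on this ring gives a 1.2-fold lower number from compound 2 to compound 3 (0.10 log units; within the scatter) and a 1.0-fold higher number from compound 1 to compound 3 (0.02 log units; within the scatter), so neither step can be told from repeat-measurement noise. This shows more than the earlier pair could: on a double-bonded chain carbon bound to a double-bonded chain carbon, the read-out stays level not only when two methoxy groups sit differently on the ring, but also when 4-bromophenyl, with 7 heavy atoms and 0 hydrogen-bond acceptors, stands in for a dimethoxyphenyl group with 10 heavy atoms and 2 acceptors. No measurement is available here that would explain why these three compounds read alike.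

Three groups, each an aromatic ring of six carbons, cannot show whether this place is insensitive to every substituent, so a ring carrying an amine or a carboxylic acid, or a plain phenyl ring, could still behave differently. On these data alone, it also remains open whether replacing the ring with a saturated alkyl chain, or lengthening the chain that holds it, would move the number beyond the scatter.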